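Removing the hydroxy from the core of compound 3

The source may report more compounds than this note shows. Statements on the series, on what has been measured and on what is new or still open speak of the compounds shown alone.

Measured compounds:
- Compound 1, `O=c1[nH]ccc2nc(N3CCC(Oc4ccccc4C(F)(F)F)CC3)sc12`: 85 nM
- Compound 2, `Nc1ncnc2nc(N3CCC(Oc4ccccc4C(F)(F)F)CC3)sc12`: 56 nM
- Compound 3, `Oc1nc2cnc(N3CCC(Oc4ccccc4C(F)(F)F)CC3)nc2[nH]1`: 38 nM

All three were tested in an assay on microsomes from liver for inhibition of acyl-CoA desaturase 1 (Rattus norvegicus); a lower number here means a stronger inhibitor, a higher number a weaker inhibitor. Compound 3 gives the lowest number of the three; its gap to compound 2 lies within the scatter, so the two cannot be ordered, while its gap to compound 1 lies beyond it.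

Compound 4, `FC(F)(F)c1ccccc1OC1CCN(c2ncc3nc[nH]c3n2)CC1`, has not yet been measured. It differs from compound 3 by hydrogen in place of hydroxy on an aromatic carbon, on an aromatic carbon of a five-membered aromatic ring with two nitrogen, between two ring nitrogen atoms. For the measured compounds named here, no measured pair shows this change, so only a cautious guess is possible. A modest weakening is expected, a 1.7-fold higher number from compound 3 to compound 4 (0.23 log units; within the scatter), though a step no larger than the scatter is also plausible. Compound 4 is estimated at 65 nM, within 25 nM to 170 nM.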

Compound 4, half-maximal inhibitory concentration: 10 nM
Compound 4: middle estimate off by 6.5-fold (0.81 log units), on the high side; the measured number lies below the stated range.
By their numbers in this assay, from the lowest: compound 4; then compounds 3, 2 and 1 (each within the scatter of the next, the first and the last beyond it).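

In this assay, the hydroxy is not needed at this position, on an aromatic carbon between two ring nitrogen atoms: hydrogen in its place gives a 3.8-fold lower number from compound 3 to compound 4 (0.58 log units; beyond the scatter), a step beyond the scatter towards a stronger inhibitor. This is the only pair shown that differs in one place, so it gives the first direct reading of any single change in this set. Nothing available explains the lower number.

The compounds shown leave open how a methyl group or an amine would read on this same carbon. From the compounds shown here alone, whether removing the hydroxy has the same effect on other cores also remains open.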